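The source may report more compounds than this note shows. Statements on the series, on what has been measured and on what is new or still open speak of the compounds shown alone.

Measured so far in a functional assay on HCT-15 cells (Homo sapiens) for cytotoxicity, read by MTT assay, with a stated time of 2 days; on this read-out lower numbers stand for stronger inhibition and higher numbers for weaker inhibition:

- compound 1 `Cc1ccc2c(=O)[nH]c(-c3ccccc3C)nc2c1`: 11900 nM
- compound 2 `Cc1ccc2nc(-c3ccccc3C(F)(F)F)[nH]c(=O)c2c1`: > 50000 nM (a limit of the assay, not a number)

Within the data shown here, compound 1, at 11900 nM, holds the only true number so far, so it is the sole firm reference point. The only other result is the limit reached by compound 2, which shows no measurable potency in this assay up to that ceiling.

The next compound to be tested is compound 3 `Cc1ccc2c(=O)[nH]c(-c3ccccc3F)nc2c1`. It differs from compound 1 by one small swap: fluoro in place of methyl on an aromatic carbon. The rest of the molecule stays the same.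

Among the measured compounds shown here, no measured pair in this set shows what such a swap does, so any forecast is loose. A single-atom replacement like this one is expected to change little, with a slight drift toward weaker inhibition more likely than a gain. The expected move a 1.3-fold higher number from compound 1 to compound 3 (0.13 log units; within the scatter) is therefore small. For compound 3 the estimated value is 16000 nM, with an expected range from 6000 nM to 45000 nM.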

Compound 3, half-maximal inhibitory concentration: 10300 nM
Compound 3: the middle estimate sits 1.6-fold (0.19 log units) above what was measured; the measured number falls inside the stated range.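

In this assay, putting fluoro in place of methyl on an aromatic carbon, ortho to a large group, gives a 1.2-fold lower number from compound 1 to compound 3 (0.06 log units; within the scatter). Among these compounds, this is the first step in the set that changes only one place, and it gives this position its first direct reading: the two compounds cannot be told apart in this test, so the methyl group of compound 1 is not required for the cytotoxicity seen here, as fluoro serves equally well at that spot. This holds for this one pair only, and nothing measured here bears on why the two groups read alike.

On these data alone, whether a quite different group at the same place, such as an amine, a methoxy group or a carboxylic acid, would also leave the number unchanged remains open. The result for compound 2 is a limit and not a number, and that compound differs from compound 1 in more than one place, so it cannot be read as a step and does not help to settle this.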